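A few compounds are considered here, and "the series" means these few. Any claim that something is new, unique, unknown or untested is made for them only; others in the source may bear on it.

In a functional assay on HO8910 cells (Homo sapiens) for cytotoxicity, read by CCK-8 assay, with a stated time of 24 h (on this read-out lower numbers stand for stronger inhibition and higher numbers for weaker inhibition), three compounds have been measured.
Compound 1, `C/C(=C\c1cc(-c2ccc(C#N)cc2)cs1)C(N)=O`, gives 130 nM.
Compound 2, `C/C(=C\c1cc(-c2ccc(C(F)(F)F)cc2)cs1)C(N)=O`, gives > 50000 nM, which is a limit of the assay rather than a number.
Compound 3, `COc1ccc(-c2csc(/C=C(\C)C(N)=O)c2)cc1`, gives > 50000 nM, likewise a limit of the assay and not a number.

Compound 3 therefore stands at the top of what was recorded, where (the limit of > 50000 nM in this assay, at which 2 of the 3 values shown sit). Compound 4, `C=Cc1ccc(-c2csc(/C=C(\C)C(N)=O)c2)cc1`, differs from it by vinyl in place of methoxy on an aromatic carbon. The step of an at least 380-fold higher number from compound 1 to compound 3 (2.58 log units; beyond the scatter) shows how far the methoxy compound lies from the cyano compound, while the step that the two limits leave unreadable from compound 2 to compound 3 cannot be sized. For the measured compounds named here, no measured step swaps methoxy for vinyl, so the size of the change to compound 4 remains open. Compound 4 is expected to stay near the limit, with an estimated 40000 nM (range 4000 nM to 200000 nM) in this assay, meaning an expected step of an at least 1.2-fold lower number from compound 3 to compound 4 (0.09 log units; that floor lies within the scatter).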

Compound 4, half-maximal inhibitory concentration: > 50000 nM
Compound 4: a limit, no number (the forecaster's own chance of this, stated with the estimate: 70%); middle value at least 1.2-fold (0.09 log units) from the limit.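

Putting vinyl in place of cyano gives an at least 380-fold higher number from compound 1 to compound 4 (2.58 log units; beyond the scatter), so a third group on this aromatic carbon, para to a large group, fails to keep the value of compound 1. The steps among compound 2, compound 3 and compound 4 cannot be read, as each of these values is a limit and not a number. Of the groups shown, only cyano gives a measured number here: the limit of > 50000 nM in this assay, at which 3 of the 4 values shown sit.

Going by these compounds, it remains open whether cyano alone gives a measured number at this position, or whether a carboxylic acid, an amine or a nitro group would too. On these data alone, how far compound 2, compound 3 and compound 4 lie beyond their shared limit also remains open.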